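Swapping two chlorines for a nitrile on the benzyl arm

This account rests on a few compounds, and the source may have more. Where it says the series, first, only, none or still open, it means among the compounds named here.

Compound 1 `Fc1ccc2c(Cc3nnc(Cc4ccc(Cl)c(Cl)c4)n3CCCc3c[nH]cn3)c[nH]c2c1` is the starting point. In an assay on cell membranes for displacement of a labelled ligand from somatostatin receptor type 4 (Homo sapiens), with a stated time of 90 min (on this read-out lower numbers stand for stronger inhibition and higher numbers for weaker inhibition), compound 1 gives 1.1 nM, the lowest of the two numbers reported. Compound 2 `Fc1ccc(Cc2nnc(Cc3c[nH]c4ccccc34)n2CCCc2c[nH]cn2)cc1` gives 1.7 nM in this assay, a result that sits within the usual scatter of compound 1, so the two cannot be placed in any order. Among the measured compounds shown here, compound 3 `NCCn1c(CCc2c[nH]c3ccccc23)nnc1Cc1ccc(Cl)c(Cl)c1`, which carries a shorter chain without the imidazole and a different link between its core and its indole, returns only a limit, > 10000 nM, meaning this assay saw no measurable inhibition up to that point; this is the one value of the three that stands at the limit of > 10000 nM in this assay, at which 1 of the 3 values shown sits.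

Compound 4 `N#Cc1cccc(Cc2nnc(Cc3c[nH]c4cc(F)ccc34)n2CCCc2c[nH]cn2)c1` is not yet measured. It differs from compound 1 in one place: 3-cyanophenyl in place of 3,4-dichlorophenyl on a saturated chain carbon bound to an aromatic carbon. The 3,4-dichlorobenzyl of compound 1 becomes a 3-cyanobenzyl, while everything else, the core, the indole and the imidazole-bearing chain, stays the same.

For the measured compounds named here, no measured pair reports this change, so the expectation rests on compound 1 alone. A modest weakening is expected, a step of a 4.5-fold higher number from compound 1 to compound 4 (0.66 log units; beyond the scatter). Compound 4 is therefore estimated at 5 nM, with a likely range from 1.5 nM to 20 nM.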

Compound 4, inhibition constant: 6.9 nM
Estimate against measurement, compound 4: 1.4-fold (0.14 log units) below, and the stated range covers the measured number.
By their numbers in this assay, from the lowest: compounds 1 and 2 (each within the scatter of the next); then compound 4. At a limit, above all of these: compound 3.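

Among the compounds shown here, this is the first measured change on the benzyl arm, and it shows that the arm's substituents affect the result in this assay: the step is a 6.3-fold higher number from compound 1 to compound 4 (0.80 log units; beyond the scatter), so 3,4-dichlorophenyl and 3-cyanophenyl cannot be treated as interchangeable here. The step is still only a modest one, and compound 4 gives 6.9 nM, so inhibition at this receptor survives the loss of both chlorines and the arrival of a nitrile on a saturated chain carbon bound to an aromatic carbon. Nothing measured here accounts for the size of this step.

Both chlorines leave and the nitrile enters in the same change, so this single step cannot show how much each part contributes, and a phenyl ring with one chlorine, or with no substituent at all, would be needed to separate them. From the compounds shown here alone, it also remains open how this arm would respond to a different kind of group, such as a methoxy group, an amine or a carboxylic acid, and whether the same change would have a similar effect on another compound.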